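The source may report more compounds than this note shows. Statements on the series, on what has been measured and on what is new or still open speak of the compounds shown alone.

Compound 3 `COc1cccc(CNCCCNc2ccnc3cc(Oc4cccc(N(C)C)c4)ccc23)c1O` is one of three compounds built on a shared core. In a physicochemical assay for acid dissociation, compound 3 gives 9.28, level with compound 1 `COc1ccc(F)cc1CNCCCNc1ccnc2cc(Oc3cccc(N(C)C)c3)ccc12`, which gives 9.28, and together these are the lowest of three numbers; compound 2 `COc1cccc(CNCCCNc2ccnc3cc(Cc4cccc(C(F)(F)F)c4)ccc23)c1O` gives 9.47, a step of a number 0.19 log units lower from compound 2 to compound 3 (within the scatter). The other measured step, no change at the digits printed from compound 1 to compound 3 (within the scatter), alters the group on the saturated chain carbon instead. Compound 4 `COc1cccc(CNCCCNc2ccnc3cc(CC4CCCCC4)ccc23)c1O` differs from compound 3 by cyclohexylmethyl in place of 3-(dimethylamino)phenoxy on an aromatic carbon. The step of a number 0.19 log units lower from compound 2 to compound 3 (within the scatter) bears on this, since it altered the same aromatic carbon and stayed within the scatter. This assay is therefore expected to show a number 0.07 log units higher from compound 3 to compound 4 (within the scatter), nothing beyond the scatter. Compound 4 is estimated to give 9.35, within 9 and 9.7.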

Compound 4, acid dissociation constant: 9.47
The estimate for compound 4 lay 0.12 log units below the measured number, and the stated range covers the measured number.
By their numbers in this assay, from the lowest: compounds 1, 3, 2 and 4 (each within the scatter of the next).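

In this assay, the step to cyclohexylmethyl on this aromatic carbon gives a number 0.19 log units higher from compound 3 to compound 4 (within the scatter), so a group with no aromatic ring and no hydrogen-bond acceptors still stays within the scatter of 3-(dimethylamino)phenoxy. Cyclohexyl in place of 3-(trifluoromethyl)phenyl on the saturated chain carbon bound to an aromatic carbon gives no change at the digits printed from compound 2 to compound 4 (within the scatter), so that exchange of rings leaves the number unmoved at the digits printed. Nothing measured here offers an explanation for these two steps. On these data alone, whether a carboxylic acid or a primary amine on this aromatic carbon would carry the number beyond the scatter remains open.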